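The source may hold more compounds than are shown below. What is called first, only, known or untested is meant among the compounds shown, and "the series" means these compounds.

Measured in a functional assay on CaEs17 cells (Homo sapiens) for cytotoxicity, read by MTT assay, with a stated time of 72 h; on this read-out lower numbers stand for stronger inhibition and higher numbers for weaker inhibition:
compound 1 `C=C1C(=O)[C@@]23C(=O)OC[C@]4(C(=O)CCC(C)(C)[C@H]4C=O)[C@@H]2CC[C@@H]1[C@H]3OC(=O)CC`: 1400 nM
compound 2 `C=C1C(=O)[C@@]23C(=O)OC[C@]4(C(=O)CCC(C)(C)[C@H]4C=O)[C@@H]2CC[C@@H]1[C@H]3OC(=O)c1ccc(OC)cc1`: 2980 nM
compound 3 `C=C1C(=O)[C@@]23C(=O)OC[C@]4(C(=O)CCC(C)(C)[C@H]4C=O)[C@@H]2CC[C@@H]1[C@H]3OC(=O)c1ccc(C(F)(F)F)cc1`: 8960 nM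

The three compounds share one core and differ only in the group on the ester carbonyl carbon. Compound 3 has the highest number of the three, 8960 nM, which makes it the weakest inhibitor of the set. Both of its steps lie beyond the scatter: a 6.4-fold higher number from compound 1 to compound 3 (0.81 log units; beyond the scatter) and a 3.0-fold higher number from compound 2 to compound 3 (0.48 log units; beyond the scatter).

Compound 4 `C=C1C(=O)[C@@]23C(=O)OC[C@]4(C(=O)CCC(C)(C)[C@H]4C=O)[C@@H]2CC[C@@H]1[C@H]3OC(=O)c1ccccc1F` has not yet been measured. It carries 2-fluorophenyl in place of 4-(trifluoromethyl)phenyl on a carbonyl carbon whose other neighbours are: oxygen next to a carbonyl group. The counted difference reads (2-fluorophenyl in place of 4-(trifluoromethyl)phenyl on a carbonyl carbon).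

Within the data shown here, no measured compound carries 2-fluorophenyl, so no step shows this change directly. The nearest evidence is the modest step between the two aromatic esters, a 3.0-fold higher number from compound 2 to compound 3 (0.48 log units; beyond the scatter), while a 2.1-fold higher number from compound 1 to compound 2 (0.33 log units; beyond the scatter) shows a smaller modest step from ethyl to an aromatic group. Compound 4 is therefore expected to fall near compound 2 at 2980 nM, though this is uncertain. A modest estimated move toward a lower number is expected, a 2.6-fold lower number from compound 3 to compound 4 (0.41 log units; beyond the scatter). For compound 4 the estimated value in this assay is 3500 nM, with an expected range from 1500 nM to 8000 nM.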

Compound 4, half-maximal inhibitory concentration: 8550 nM
Compound 4: the middle estimate sits 2.4-fold (0.39 log units) below what was measured; measured number above the stated range.
By their numbers in this assay, from the lowest: compound 1; then compound 2; then compounds 4 and 3 (each within the scatter of the next).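

In this assay, exchanging 4-(trifluoromethyl)phenyl for 2-fluorophenyl on the carbonyl carbon makes no readable difference, a 1.0-fold lower number from compound 3 to compound 4 (0.02 log units; within the scatter), even though the entering group has fewer heavy atoms than the group it replaces. The separation from the 4-methoxyphenyl ester persists, a 2.9-fold higher number from compound 2 to compound 4 (0.46 log units; beyond the scatter), so among the three aromatic esters shown, the two that carry fluorine read alike and only the 4-methoxyphenyl ester stands apart from them. The ethyl ester also keeps its distance from this new aromatic ester, a 6.1-fold higher number from compound 1 to compound 4 (0.79 log units; beyond the scatter), and all three aromatic esters now give higher numbers than the ethyl ester.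

Nothing measured here explains why the two fluorine-bearing groups read alike. These two groups differ in both the substituent and its place on the ring, so the compounds shown cannot separate those two changes, and they leave open how a plain phenyl, a chain longer than ethyl, or a chain ending in an amine or a carboxylic acid would read at this carbonyl carbon.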